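This account rests on a few compounds, and the source may have more. Where it says the series, first, only, none or still open, it means among the compounds named here.

Compound 1 `O=C(O)C1(S(=O)(=O)c2ccc(Oc3ccc(OC(F)(F)F)cc3)cc2)CCC2(CCNCC2)C1` gives 1800 nM in a functional assay on blood (Homo sapiens), with a stated time of 60 min, in the presence of a further agent that is not named here; a higher number here means that more compound is needed for the effect, a lower number that less compound is needed. Compound 2 `O=C(Nc1ccccn1)C1(S(=O)(=O)c2ccc(Oc3ccc(OC(F)(F)F)cc3)cc2)CCC2(CCNCC2)C1` gives > 15000 nM, which is a limit of the assay and not a number. Among the compounds with values here, the one measured step is an at least 8.3-fold higher number from compound 1 to compound 2 (0.92 log units; beyond the scatter), with (pyridin-2-yl)amino in place of hydroxy on a carbonyl carbon. Compound 3 `Nc1ccccc1NC(=O)C1(S(=O)(=O)c2ccc(Oc3ccc(OC(F)(F)F)cc3)cc2)CCC2(CCNCC2)C1` keeps the amide-type nitrogen and carries 2-aminophenyl in place of pyridin-2-yl (2-aminophenyl in place of pyridin-2-yl on an amide-type nitrogen). Within the data shown here, no measured step covers this exchange, and the reference point remains (the limit of > 15000 nM in this assay, at which 1 of the 2 values shown sits). The expected outcome in this assay is a number no higher from compound 2 to compound 3 (the limit leaves the size open), with no change beyond the scatter anticipated. For compound 3 the estimate is 15000 nM, with an expected range from 4000 nM to 50000 nM.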

Compound 3, half-maximal effective concentration: 900 nM
Beside the measured number, compound 3's estimate is 17-fold (1.22 log units) above it, and the stated range ends above it.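

On the amide-type nitrogen, the group carried there matters in this assay: 2-aminophenyl in place of pyridin-2-yl gives an at least 16-fold lower number from compound 2 to compound 3 (1.22 log units; beyond the scatter). Going by these compounds, compound 2 stands at a limit of the assay and not at a number, so the full size of this step stays open: the limit of > 15000 nM in this assay, at which 1 of the 3 values shown sits. The carboxylic acid is thus not required on this core, since (2-aminophenyl)amino in place of hydroxy gives a 2.0-fold lower number from compound 1 to compound 3 (0.30 log units; within the scatter).

Still open, on these data alone, is how a plain phenyl or a 2-hydroxyphenyl on the same nitrogen would read in this assay. Such groups would show whether the amino group or the loss of the ring nitrogen carries the step.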